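Amide aryl exchange on the shared core: compound 3

The source may hold more compounds than are shown below. What is called first, only, known or untested is meant among the compounds shown, and "the series" means these compounds.

Among the measured compounds shown here, compound 2 `O=C(Nc1cc(-c2ccccc2)nn1-c1ccccc1)c1ccc(Cl)c(Cl)c1` gives the lowest of the two numbers so far: in a functional assay on cells for positive allosteric modulation of metabotropic glutamate receptor 5 (Rattus norvegicus), read by calcium flux (a lower number here means that less compound is needed, a higher number that more compound is needed for the effect), compound 2 gives 13 nM, while compound 1 `COc1ccc(C(=O)Nc2cc(-c3ccccc3)nn2-c2ccccc2)cc1` gives 54 nM. For the measured compounds named here, the one measured step, a 4.2-fold lower number from compound 1 to compound 2 (0.62 log units; beyond the scatter), shows the aryl group on the carbonyl carbon moving the number well beyond the scatter. Compound 3 `Cc1ccc(C(=O)Nc2cc(-c3ccccc3)nn2-c2ccccc2)cn1` carries 6-methylpyridin-3-yl in place of 3,4-dichlorophenyl on a carbonyl carbon. Going by the values given here, no measured step covers this exchange directly. Compound 2 holds the low end after a 4.2-fold lower number from compound 1 to compound 2 (0.62 log units; beyond the scatter). A higher number is therefore expected for compound 3, a 12-fold higher number from compound 2 to compound 3 (1.06 log units; beyond the scatter). The estimate for compound 3 is 150 nM, within 40 nM to 600 nM.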

Compound 3, half-maximal effective concentration: 280 nM
Beside the measured number, compound 3's estimate is 1.9-fold (0.27 log units) below it, and the stated range covers the measured number.
By their numbers in this assay, from the lowest: compound 2; then compound 1; then compound 3.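

In this assay the span at this place, on a carbonyl carbon, is wider than compound 1 and compound 2 alone showed: 6-methylpyridin-3-yl brings a 22-fold higher number from compound 2 to compound 3 (1.33 log units; beyond the scatter) and also a 5.2-fold higher number from compound 1 to compound 3 (0.71 log units; beyond the scatter) in the same direction. Compound 3, the only one here with a hetero atom in this ring, gives the highest number of the three. No measurement at hand explains these steps.

Whether the ring nitrogen or the methyl accounts for the rise stays open. A plain pyridin-3-yl or a 4-chlorophenyl on the carbonyl carbon would help to separate these contributions.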